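Swapping Phenylcyclopropyl for Dichlorophenyl in Compound 2

The source may report more compounds than this note shows. Statements on the series, on what has been measured and on what is new or still open speak of the compounds shown alone.

Compound 2 `C[C@H](NC(=O)C(=O)NCC1(c2ccccc2)CC1)C(=O)N[C@@H](CC(=O)O)C(=O)COc1c(F)c(F)cc(F)c1F` was tested in a functional assay on Jurkat cells (Homo sapiens) (on this read-out lower numbers stand for stronger inhibition and higher numbers for weaker inhibition), where compound 2 gives 27 nM, the second highest of three numbers. Compound 1 `C[C@H](NC(=O)C(=O)NCCC1CCCC1)C(=O)N[C@@H](CC(=O)O)C(=O)COc1c(F)c(F)cc(F)c1F` gives 11 nM, and compound 3 `Cc1ccccc1CNC(=O)C(=O)N[C@@H](C)C(=O)N[C@@H](CC(=O)O)C(=O)COc1c(F)c(F)cc(F)c1F` gives 52 nM. The step of a 2.5-fold higher number from compound 1 to compound 2 (0.39 log units; beyond the scatter) and the step of a 4.7-fold higher number from compound 1 to compound 3 (0.67 log units; beyond the scatter) lie beyond the scatter, while the step of a 1.9-fold higher number from compound 2 to compound 3 (0.28 log units; within the scatter) lies within it. Compound 4 `C[C@H](NC(=O)C(=O)NCc1ccc(Cl)cc1Cl)C(=O)N[C@@H](CC(=O)O)C(=O)COc1c(F)c(F)cc(F)c1F` differs from compound 2 by 2,4-dichlorophenyl in place of 1-phenylcyclopropyl on a saturated chain carbon bound to an amide-type nitrogen. The nearest measured step, a 1.9-fold higher number from compound 2 to compound 3 (0.28 log units; within the scatter), also put a substituted phenyl in place of 1-phenylcyclopropyl at the same place and stayed within the scatter, so a similarly small shift, toward a higher number if anything, is expected, and the step of a 1.5-fold higher number from compound 2 to compound 4 (0.17 log units; within the scatter) is the estimate. Compound 4 is estimated at 40 nM, with a range from 15 nM to 110 nM.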

Compound 4, half-maximal inhibitory concentration: 165 nM
Estimate against measurement, compound 4: 4.1-fold (0.62 log units) below, outside the stated range (above it).
By their numbers in this assay, from the lowest: compound 1; then compounds 2 and 3 (each within the scatter of the next); then compound 4.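

In this assay, a substituted phenyl at this position is not always a small change: 2,4-dichlorophenyl gives a 6.1-fold higher number from compound 2 to compound 4 (0.79 log units; beyond the scatter), whereas 2-methylphenyl had stayed within the scatter of 1-phenylcyclopropyl. The two substituted phenyl groups also separate, with a 3.2-fold higher number from compound 3 to compound 4 (0.50 log units; beyond the scatter), and a 15-fold higher number from compound 1 to compound 4 (1.18 log units; beyond the scatter) shows that the position spans a far wider range than the first three compounds revealed. No available evidence explains this rise.

The compounds shown leave open whether the higher number requires both chlorines. They also leave open how a phenyl carrying a single chlorine or a methoxy group would read.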